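The source may hold more compounds than are shown below. What is called first, only, known or untested is meant among the compounds shown, and "the series" means these compounds.

Measured so far: compound 1 `CCC(CC)CNc1c(C(N)=O)cnc2ccc(C#N)cc12` with 820 nM; compound 2 `NC(=O)c1cnc2ccc(-c3cccnc3)cc2c1NC1CCCC1` with 137 nM; compound 3 `C[C@H](Nc1c(C(N)=O)cnc2ccc(-c3cccnc3)cc12)C1CCOCC1` with 168 nM.

In an assay on HT-29 cells for inhibition of Serine-protein kinase ATM (Homo sapiens), read by fluorescence, with a stated time of 1 h (on this read-out higher numbers stand for weaker inhibition and lower numbers for stronger inhibition), compound 1 gives 820 nM, the highest number of the three; the values of compound 2 and compound 3 both lie lower, beyond the scatter. Within the data shown here, compound 2 and compound 3 share the pyridin-3-yl group and differ from compound 1 in two places, so no single step to compound 1 is available.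

Compound 4 `CCC(CC)CNc1c(C(N)=O)cnc2ccc(-c3cncnc3)cc12` keeps the 2-ethylbutylamine of compound 1 and changes the aryl position: pyrimidin-5-yl in place of cyano on an aromatic carbon.

Among the measured compounds shown here, the only single-place step measured, a 1.2-fold higher number from compound 2 to compound 3 (0.09 log units; within the scatter), concerns the amine side and is within the scatter. For the measured compounds named here, that makes the lower numbers of compound 2 and compound 3 attributable chiefly to the aryl group, though no step from cyano to pyridin-3-yl or to pyrimidin-5-yl has itself been measured. For compound 4 a lower number than compound 1 is therefore expected, roughly in the region of compound 2 and compound 3; the expected step is a 3.7-fold lower number from compound 1 to compound 4 (0.57 log units; beyond the scatter). The estimate for compound 4 is 220 nM, in the range 80 nM to 600 nM.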

Compound 4, half-maximal inhibitory concentration: 1840 nM
Beside the measured number, compound 4's estimate is 8.4-fold (0.92 log units) below it, outside the stated range (above it).
By their numbers in this assay, from the lowest: compounds 2 and 3 (each within the scatter of the next); then compound 1; then compound 4.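

In this assay, among these compounds, the change of pyrimidin-5-yl in place of cyano on the shared core gives the first single-place reading at this aromatic carbon (a 2.2-fold higher number from compound 1 to compound 4 (0.35 log units; beyond the scatter)), a modest step but one beyond the scatter. With the 2-ethylbutylamine held constant, an aromatic ring at this position therefore does not by itself bring a lower number, so the lower values of compound 2 and compound 3, which carry pyridin-3-yl and other amine groups, cannot be credited to the presence of an aromatic ring alone. No measurement shown here accounts for the direction of this step.

Still open, going by these compounds, is how pyridin-3-yl itself compares with cyano or pyrimidin-5-yl when the 2-ethylbutylamine is kept. The compounds shown also say nothing about phenyl at this position, or about how the aryl and amine groups combine.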